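Replacing the furan in a two-compound series

The compounds below may be only part of what the source reports. "The series", "measured", "known", "first", "only" and "open" are said of these compounds alone.

Measured in a functional assay on HL-60 cells (Homo sapiens) for antiproliferative activity, read by XTT assay, with a stated time of 72 h (on this read-out higher numbers stand for weaker inhibition and lower numbers for stronger inhibition), so far:
- compound 1 `C=C(C)CCC[C@]1(C)C2=CCC[C@](C)(C[C@H](OC(C)=O)C3=CC(=O)OC3O)[C@H]2CC[C@H]1C` gives 3000 nM
- compound 2 `C=C(C)CC[C@]1(C)C2=CCC[C@](C)(C[C@H](O)c3ccoc3)[C@H]2CC[C@H]1C` gives 28700 nM

Compound 2 at 28700 nM has the higher of the two numbers and so the weaker inhibition, and the gap to compound 1 lies beyond the scatter. Compound 3 `C=C(C)CC[C@]1(C)C2=CCC[C@](C)(C[C@@H](O)C3=CC(=O)OC3O)[C@H]2CC[C@H]1C` is still unmeasured. The change from compound 2 to compound 3 is a group of 9 heavy atoms (5 carbon, 4 oxygen; one five-membered non-aromatic ring with 1 hetero atom) in place of a group of 7 heavy atoms (5 carbon, 2 oxygen; one five-membered aromatic ring with 1 hetero atom), on a saturated chain carbon bound to a saturated ring carbon and the entering group holds 2 double bonds outside aromatic rings.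

Among the compounds with values here, no measured pair isolates this change. Compound 1 carries a five-membered non-aromatic ring of the kind that enters here and reads 3000 nM in this assay but also differs from compound 2 in other places, so it is only a loose guide. With just two values, the expectation is uncertain. The expected change is a fall in the number, towards stronger inhibition, estimated as a 4.8-fold lower number from compound 2 to compound 3 (0.68 log units; beyond the scatter) in this assay and so probably beyond the scatter. Compound 3 is estimated at 6000 nM with 2000 nM to 20000 nM as its expected range.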

Compound 3, half-maximal inhibitory concentration: 3300 nM
The estimate for compound 3 lay 1.8-fold (0.26 log units) above the measured number; the measured number falls inside the stated range.
By their numbers in this assay, from the lowest: compounds 1 and 3 (each within the scatter of the next); then compound 2.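

In this assay, the exchange of the (furan-3-yl)(hydroxy)methyl group for the group carrying the five-membered non-aromatic ring gives an 8.7-fold lower number from compound 2 to compound 3 (0.94 log units; beyond the scatter), on a saturated chain carbon bound to a saturated ring carbon. Within the data shown here, until now, this kind of ring had been seen only in compound 1, which also differs from compound 2 in other places, so its effect could not be separated from those differences; this pair shows that the change at this one place is enough to produce a step beyond the scatter, with no other difference in the structure. No measurement of any other kind is available to explain the step.

The two groups differ in several counted features at once, including the aromatic ring, the double bonds outside aromatic rings and the numbers of hydrogen-bond donors and acceptors, so this single step cannot assign the shift to any one of them. Going by these compounds, it also remains open how this position would read with a carboxylic acid or an amine in place of the ring, and whether the step would carry over to cell lines other than HL-60.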